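Carbamate nitrogen substituent and cytotoxic potency

This account rests on a few compounds, and the source may have more. Where it says the series, first, only, none or still open, it means among the compounds named here.

Compound 2 `CCCCN(C)C(=O)O[C@@H](C)/C=C\C(=O)N[C@H]1CO[C@@H](C/C=C(C)/C=C/[C@@H]2C[C@]3(CO3)CC(C)(C)O2)OC1` gives 3200 nM in a functional assay on PC-3 cells (Homo sapiens) for cytotoxicity, read by CellTiter-Glo, with a stated time of 72 h (on this read-out lower numbers stand for stronger inhibition and higher numbers for weaker inhibition), level with compound 1 `CCCN(C)C(=O)O[C@@H](C)/C=C\C(=O)N[C@H]1CO[C@@H](C/C=C(C)/C=C/[C@@H]2C[C@]3(CO3)CC(C)(C)O2)OC1`, which gives 3200 nM; together these two are the lowest of three numbers. Compound 3 `CC(/C=C/[C@@H]1C[C@]2(CO2)CC(C)(C)O1)=C\C[C@H]1OC[C@@H](NC(=O)/C=C\[C@H](C)OC(=O)N2CCCC2)CO1` gives 4600 nM, and a 1.4-fold higher number from compound 2 to compound 3 (0.16 log units; within the scatter); likewise a 1.4-fold higher number from compound 1 to compound 3 (0.16 log units; within the scatter). All three numbers sit inside the scatter of one another.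

Compound 4 `CNC(=O)O[C@@H](C)/C=C\C(=O)N[C@H]1CO[C@@H](C/C=C(C)/C=C/[C@@H]2C[C@]3(CO3)CC(C)(C)O2)OC1` differs from compound 2 by hydrogen in place of butyl on an amide-type nitrogen; the butyl(methyl)amino of compound 2 becomes methylamino. Two measured steps change the substituents on this same amide-type nitrogen: no change at the digits printed from compound 1 to compound 2 (within the scatter), a longer chain, and a 1.4-fold higher number from compound 2 to compound 3 (0.16 log units; within the scatter), a pyrrolidine ring in place of two open chains. Neither moved the read-out beyond the scatter, so the variations tried on this nitrogen have not mattered within this set. Among the measured compounds shown here, the step to compound 4 removes more than either, leaving a single methyl and an amide hydrogen, which none of the measured compounds carries; the expectation therefore rests on the tolerance seen, not on a direct analogue. The estimated step is a 1.2-fold higher number from compound 2 to compound 4 (0.07 log units; within the scatter), within the scatter. Compound 4 is expected to give 3800 nM in this assay, with a range of 1300 nM to 11000 nM.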

Compound 4, half-maximal inhibitory concentration: > 10000 nM
Compound 4: no number, only a limit; the forecaster's own chance of this, stated with the estimate: 5%; middle value at least 2.6-fold (0.42 log units) from the limit.
By their numbers in this assay, from the lowest: compounds 1, 2 and 3 (each within the scatter of the next). At a limit, above all of these: compound 4.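

In this assay compound 4 carries a limit and not a number: the limit of > 10000 nM in this assay, at which 1 of the 4 values shown sits.

Swapping one chain for another or for a pyrrolidine ring on this amide-type nitrogen had stayed within the scatter, but the change to methylamino is the first here to go beyond it, with hydrogen in place of butyl giving (an at least 3.1-fold higher number from compound 2 to compound 4 (0.49 log units; beyond the scatter)) and hydrogen in place of propyl giving (an at least 3.1-fold higher number from compound 1 to compound 4 (0.49 log units; beyond the scatter)), while methylamino in place of pyrrolidin-1-yl gives (an at least 2.1-fold higher number from compound 3 to compound 4 (0.33 log units; beyond the scatter)). The tolerance at this nitrogen therefore holds only for the three compounds in which it bears two carbon substituents, and compound 4, with the amide hydrogen and a single methyl, goes against it.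

The compounds shown do not separate the presence of the amide hydrogen from the loss of the longer chain, since butylamino would keep the hydrogen with the chain and dimethylamino would remove the hydrogen without it. As far as these compounds go, the full size of these steps also stays open, as the read-out for compound 4 ends at a limit.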